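Methyl for fluoro on the thiourea aryl of compound 3

The compounds below may be only part of what the source reports. "The series", "measured", "known", "first", "only" and "open" are said of these compounds alone.

Three thiourea analogues on a shared core have been measured in a functional assay on A549 cells (Homo sapiens) for inhibition, read by CCK-8 assay, with a stated time of 48 h; on this read-out lower numbers stand for stronger inhibition and higher numbers for weaker inhibition. Compound 1 `Cc1ccc(NC(=S)NC(=O)c2cn(-c3ccccc3)nc2-c2ccc(F)cc2)cc1` gives 2080 nM, compound 2 `COc1ccc(NC(=S)NC(=O)c2cn(-c3ccccc3)nc2-c2ccc(OC)cc2)cc1` gives 750 nM, and compound 3 `COc1ccc(-c2nn(-c3ccccc3)cc2C(=O)NC(=S)Nc2ccc(F)cc2)cc1` gives 1430 nM. On these numbers compound 3 stands second highest of the three; its nearest neighbour is compound 1 and its furthest is compound 2, yet both gaps lie within the scatter, so no order among the three can be read from this assay.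

Among the compounds with values here, the only single-place step recorded, a 1.9-fold higher number from compound 2 to compound 3 (0.28 log units; within the scatter), swaps fluoro for methoxy and stays within the scatter.

Compound 4 `COc1ccc(-c2nn(-c3ccccc3)cc2C(=O)NC(=S)Nc2ccc(C)cc2)cc1` differs from compound 3 by methyl in place of fluoro on an aromatic carbon, sitting para to a large group on a six-membered aromatic ring of carbon only; the same difference, cut one bond further out, reads 4-fluorophenyl to 4-methylphenyl. Within the data shown here, no measured step covers exactly this change. Among the measured compounds shown here, compound 1, which carries the (4-methylphenyl)amino group in the same place, and compound 3, which carries the (4-fluorophenyl)amino group, show values within the scatter of each other, and the one recorded step was also flat. A step of no size beyond the scatter is therefore expected for compound 4 in this assay, a 1.1-fold higher number from compound 3 to compound 4 (0.05 log units; within the scatter). Compound 4 is estimated at 1600 nM, with a range from 700 nM to 3800 nM.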

Compound 4, half-maximal inhibitory concentration: 1250 nM
Beside the measured number, compound 4's estimate is 1.3-fold (0.11 log units) above it; the measured number falls inside the stated range.
By their numbers in this assay, from the lowest: compounds 2, 4, 3 and 1 (each within the scatter of the next, the first and the last beyond it).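

In this assay, methyl in place of fluoro on an aromatic carbon, para to a large group, now has a direct reading: a 1.1-fold lower number from compound 3 to compound 4 (0.06 log units; within the scatter), so this change is flat at this place on the core of compound 3. Methyl in place of methoxy at the same place gives a 1.7-fold higher number from compound 2 to compound 4 (0.22 log units; within the scatter), which means that methoxy, fluoro and methyl at this place have all been compared in direct steps, and none of these steps leaves the scatter. Methoxy in place of fluoro, read in the direction from compound 1, gives a 1.7-fold lower number from compound 1 to compound 4 (0.22 log units; within the scatter), and this change now has a second reading on another core that agrees with the first, with both steps within the scatter and close in size: the same change on two cores in this assay, a 1.9-fold higher number (0.28 log units; within the scatter) from compound 2 to compound 3 and a 1.7-fold higher number (0.22 log units; within the scatter) from compound 4 to compound 1, 1.1-fold (0.06 log units) apart, within the scatter of two such steps.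

Only methoxy, fluoro and methyl are shown at this place, so whether an amine or a carboxylic acid there would give a step beyond the scatter remains open. From the compounds shown here alone, whether these flat steps would also hold outside this assay remains open as well.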